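The source may report more compounds than this note shows. Statements on the series, on what has been measured and on what is new or still open speak of the compounds shown alone.

Series notes. Three analogues on one shared core have been run in an ADME assay on Vero cells (Chlorocebus sabaeus) for cytotoxicity, read by sulforhodamine B assay, with a stated time of 3 days; on this read-out higher numbers stand for lower toxicity in this test and lower numbers for higher toxicity in this test. Compound 1 `CC1=C(C(=O)Nc2ccc(Cl)cc2)C(c2ccccc2)C(C(=O)Nc2ccc(Cl)cc2)=C(C)N1` gives 15 ug/mL. Compound 2 `COc1ccc(C2C(C(=O)Nc3ccc(Cl)cc3)=C(C)NC(C)=C2C(=O)Nc2ccc(Cl)cc2)cc1` gives 20 ug/mL. Compound 3 `CC1=C(C(=O)Nc2ccc(Cl)cc2)C(c2ccncc2)C(C(=O)Nc2ccc(Cl)cc2)=C(C)N1` gives 78 ug/mL. Compound 3 holds the highest number of the three: the two steps up to it, a 3.9-fold higher number from compound 2 to compound 3 (0.59 log units; beyond the scatter) and a 5.2-fold higher number from compound 1 to compound 3 (0.72 log units; beyond the scatter), are both beyond the scatter, whereas a 1.3-fold higher number from compound 1 to compound 2 (0.12 log units; within the scatter) stays within it.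

Compound 4 `CC1=C(C(=O)Nc2ccc(Cl)cc2)C(c2cccc(Cl)c2)C(C(=O)Nc2ccc(Cl)cc2)=C(C)N1` has not yet been measured. The change from compound 3 is: 3-chlorophenyl in place of pyridin-4-yl on a saturated ring carbon. The two steps that bear on it are the ones that swapped the group on the same saturated ring carbon, a 5.2-fold higher number from compound 1 to compound 3 (0.72 log units; beyond the scatter) and a 3.9-fold higher number from compound 2 to compound 3 (0.59 log units; beyond the scatter); both moved the number up on going to pyridin-4-yl. Compound 4 goes the other way, back to a six-membered aromatic ring of carbon only, so a modest step down in this assay is expected, toward the values of compound 1 and compound 2. Within the data shown here, the effect of the chlorine on the incoming ring has no precedent in this set, which widens the range. For compound 4 the expected step is a 3.9-fold lower number from compound 3 to compound 4 (0.59 log units; beyond the scatter). Compound 4 is therefore estimated at 20 ug/mL, with a range from 8 ug/mL to 50 ug/mL.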

Compound 4, half-maximal cytotoxic concentration: 12 ug/mL
The estimate for compound 4 lay 1.7-fold (0.22 log units) above the measured number, and the stated range covers the measured number.
By their numbers in this assay, from the lowest: compounds 4, 1 and 2 (each within the scatter of the next); then compound 3.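

In this assay, replacing pyridin-4-yl with 3-chlorophenyl on the saturated ring carbon gives a 6.5-fold lower number from compound 3 to compound 4 (0.81 log units; beyond the scatter), so the higher number of compound 3 now stands apart from three compounds bearing a six-membered aromatic ring of carbon only, with none of the four compounds going against this. Adding chlorine to the phenyl ring of compound 1 gives a 1.3-fold lower number from compound 1 to compound 4 (0.10 log units; within the scatter), and replacing 4-methoxyphenyl with 3-chlorophenyl gives a 1.7-fold lower number from compound 2 to compound 4 (0.22 log units; within the scatter), so these carbon-only rings cannot be told apart in this test, whichever of the substituents shown they carry. Nothing available explains why the number shifts with the group at this position.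

The compounds shown leave open whether the higher number belongs to pyridin-4-yl alone or would also appear with pyridin-3-yl, a pyrimidine ring, or a phenyl ring bearing an amine or a carboxylic acid. Also open, going by these compounds, are whether 4-chlorophenyl would read the same as 3-chlorophenyl and whether changing the two (4-chlorophenyl)carbamoyl groups would shift the number of compound 3.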